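This account rests on a few compounds, and the source may have more. Where it says the series, first, only, none or still open, it means among the compounds named here.

Compound 1 `CC(C)C(Cc1nnc[nH]1)c1ccc(-c2ccc3cccc(F)c3c2)[nH]c1=O` sits at the low end of the two results gathered in an ADME assay on microsomes from liver (Rattus norvegicus) for metabolic stability (on this read-out lower numbers stand for a shorter-lived compound and higher numbers for a longer-lived compound), where compound 1 gives 0.1 h. Compound 2 `CCn1ncc2c(F)cc(-c3ccc(C(CC)(CC)c4nnc(C)[nH]4)c(=O)[nH]3)cc21` is reported in this assay only as a limit, with compound 2 at > 3 h. For the measured compounds named here, that limit is described as the limit of > 3 h in this assay, at which 1 of the 2 values shown sits, so the gap between the two compounds cannot be sized; it can only be said that compound 1 is the one with a number.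

Compound 3 `CC(C)C(CC(N)=O)c1ccc(-c2ccc3cccc(F)c3c2)[nH]c1=O` is the unmeasured partner of compound 1. It differs in one place: carbamoyl in place of 4H-1,2,4-triazol-3-yl on a saturated chain carbon, two bonds along the chain from an aromatic carbon.

No measured step of this kind exists among the compounds shown, so the expectation rests on compound 1 alone. The step from compound 1 to compound 3 in this assay is expected to be modest, a 1.5-fold higher number from compound 1 to compound 3 (0.18 log units; within the scatter), and not clearly beyond the scatter in either direction. Compound 3 is therefore estimated to give 0.15 h, expected to fall between 0.05 h and 0.6 h.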

Compound 3, half-life: < 0.0667 h
Compound 3 ended at the assay's limit; the forecaster's own chance of this, stated with the estimate: 5%; middle value at least 2.2-fold (0.35 log units) away from the limit.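

In this assay, carbamoyl in place of 4H-1,2,4-triazol-3-yl on a saturated chain carbon, two bonds along the chain from an aromatic carbon, gives an at least 1.4-fold lower number from compound 1 to compound 3 (0.17 log units; that floor lies within the scatter). Compound 3 is reported only as a limit of the assay, not as a number: the limit of < 0.0667 h in this assay, at which 1 of the 3 values shown sits. Going by these compounds, the step therefore shows that carbamoyl at this place leaves the compound at the short-lived end of the read-out, which compound 1 alone could not show, while the true size of the step stays unknown and its floor does not clear the scatter.

On these data alone, how a carboxylic acid or an amine on this same chain would read remains open. Compound 2 differs from compound 1 and compound 3 in more than one place, so it says nothing about this position.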